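This account rests on a few compounds, and the source may have more. Where it says the series, first, only, none or still open, it means among the compounds named here.

Measured compounds in a functional assay on HCT-116 cells (Homo sapiens) for inhibition, read by sulforhodamine B assay, with a stated time of 48 h; on this read-out lower numbers stand for stronger inhibition of growth and higher numbers for weaker inhibition of growth:
compound 1 `O=C(Nc1cccc(-n2cc(-c3ccncc3)c(-c3ccc(Cl)c(O)c3)n2)c1)Nc1cccc(C(F)(F)F)c1` gives 1390 nM
compound 2 `COc1cc(-c2nn(-c3cccc(NC(=O)Nc4cccc(C(F)(F)F)c4)c3)cc2-c2ccncc2)ccc1Cl` gives 900 nM

Compound 2 stands at the lowest of the two numbers in this assay, but its nearest neighbour is compound 1, and the step of a 1.5-fold lower number from compound 1 to compound 2 (0.19 log units; within the scatter) is within the scatter, so the two cannot be told apart on this read-out. That step rests on a single change, methyl in place of hydrogen on an oxygen on an aromatic ring.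

Compound 3 `COc1cc(-c2nn(-c3cccc(NC(=O)c4ccccc4)c3)cc2-c2ccncc2)ccc1Cl` is not yet measured. It differs from compound 2 in one place: phenyl in place of (3-(trifluoromethyl)phenyl)amino on a carbonyl carbon. Among the compounds with values here, this change does not touch the part of the shared core that was altered between compound 1 and compound 2, so no measured step bears on it. Within the data shown here, the only step known, a 1.5-fold lower number from compound 1 to compound 2 (0.19 log units; within the scatter), gives no guide to what a change at the carbonyl carbon does. The expectation therefore rests on little, and a wide range is warranted; compound 3 is expected to give 3500 nM, with a range from 700 nM to 20000 nM, which amounts to an expected step of a 3.9-fold higher number from compound 2 to compound 3 (0.59 log units; beyond the scatter).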

Compound 3, concentration for 50% growth inhibition: 500 nM
Compound 3: middle estimate off by 7.0-fold (0.85 log units), on the high side; measured number outside the range, below it.
By their numbers in this assay, from the lowest: compounds 3, 2 and 1 (each within the scatter of the next, the first and the last beyond it).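

In this assay, phenyl in place of (3-(trifluoromethyl)phenyl)amino on the carbonyl carbon gives a 1.8-fold lower number from compound 2 to compound 3 (0.26 log units; within the scatter), so compound 2 and compound 3 cannot be told apart on this read-out. Within the data shown here, this is the first reading at this position, as the earlier step concerned only the group on the oxygen, and it shows that the read-out stays within the scatter even though the group that leaves has 11 heavy atoms and 1 hydrogen-bond donor, while the phenyl that enters has 6 heavy atoms and 0 hydrogen-bond donors. No measurement here offers an explanation for this result.

The amino nitrogen and the trifluoromethyl group leave together in this single step, so their separate contributions remain unresolved, and a plain phenylamino group or a 3-(trifluoromethyl)phenyl group on the carbonyl carbon would be needed to separate them. On these data alone, it also remains open how groups of another kind at this position would read in this assay, such as a short alkyl chain, a cyclohexyl ring or a phenyl ring carrying a carboxylic acid.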